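A few compounds are considered here, and "the series" means these few. Any claim that something is new, unique, unknown or untested is made for them only; others in the source may bear on it.

Measured in a functional assay on A549 cells (Homo sapiens) for inhibition, read by sulforhodamine B assay, with a stated time of 72 h; a higher number here means a weaker inhibitor of growth, a lower number a stronger inhibitor of growth:
- compound 1 `NNC(=O)CCc1ccncc1-c1ccc2ccccc2c1`: > 10000 nM
- compound 2 `O=C(O)/C=C/c1ccncc1-c1ccc2ccccc2c1`: > 10000 nM
- compound 3 `O=C(O)CCc1ccncc1-c1ccc2ccccc2c1`: > 10000 nM

Compound 3 stands at the limit of > 10000 nM in this assay, at which 3 of the 3 values shown sit, which is a limit and not a number. Compound 4 `O=C(/C=C/c1ccncc1-c1ccc2ccccc2c1)NC1CC1` carries 2-(cyclopropylcarbamoyl)ethenyl in place of 2-carboxyethyl on an aromatic carbon.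

Going by the values given here, three measured steps bear on this change: a step that the two limits leave unreadable from compound 1 to compound 2, a step that the two limits leave unreadable from compound 1 to compound 3 and a step that the two limits leave unreadable from compound 2 to compound 3. Among the compounds with values here, none of them has a readable size, so they offer no size to carry over, and no measured compound holds the incoming group. The expected a number no higher from compound 3 to compound 4 (the limit leaves the size open) is therefore small and uncertain, and any shift would be towards stronger inhibition of growth. The estimate for compound 4 is 10000 nM, with an expected range of 3000 nM to 30000 nM.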

Compound 4, concentration for 50% growth inhibition: 5840 nM
The estimate for compound 4 lay 1.7-fold (0.23 log units) above the measured number; low and high end bracket the measured number.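

Going by these compounds alone, at this position, opposite the ring nitrogen, compound 4 gives the first true number in this assay: 5840 nM. The others offer only a limit: the limit of > 10000 nM in this assay, at which 3 of the 4 values shown sit. The steps are therefore floors, not full sizes: an at least 1.7-fold lower number from compound 3 to compound 4 (0.23 log units; that floor lies within the scatter), an at least 1.7-fold lower number from compound 2 to compound 4 (0.23 log units; that floor lies within the scatter) and an at least 1.7-fold lower number from compound 1 to compound 4 (0.23 log units; that floor lies within the scatter).

The cyclopropyl ring and the double bond arrive together in the step from the saturated acid, so their shares cannot be separated. A saturated 2-(cyclopropylcarbamoyl)ethyl chain, or an ethenyl amide carrying a methyl or isopropyl group on nitrogen, would help to separate them.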